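The source may report more compounds than this note shows. Statements on the series, on what has been measured and on what is new or still open speak of the compounds shown alone.

Of the compounds shown here, three built on a shared core have been tested in a functional assay on A-375 cells (Homo sapiens) for antiproliferative activity, read by CCK-8 assay, with a stated time of 72 h, tested at 2 uM; a lower number here means a weaker effect, a higher number a stronger effect of the compound at the concentration tested. Compound 1 `Nc1ccccc1NC(=O)c1ccc(CSC(=S)N2CCN(c3ccccc3)CC2)cc1` gives 27.5%. Compound 2 `Nc1ccccc1NC(=O)c1ccc(CSC(=S)N2CCc3ccccc32)cc1` gives 25.7%, and compound 3 `Nc1ccccc1NC(=O)c1ccc(CSC(=S)N(Cc2ccccc2)Cc2ccccc2)cc1` gives 10.9%. Compound 1 holds the top number of the three, though the reading for compound 2 lies within the usual scatter of it, so those two cannot be told apart; only the gap between compound 1 and compound 3 lies beyond that scatter. Compound 4 `Nc1ccccc1NC(=O)c1ccc(CSC(=S)N2CCN(c3cnccn3)CC2)cc1` has not yet been measured. It differs from compound 1 in a single place: pyrazin-2-yl in place of phenyl on an amine nitrogen in a ring. Among the measured compounds shown here, no measured pair shows what this exchange does to the read-out, since the three measured compounds vary in a different part of the molecule. The change is expected to make a small step, with no direction that can be claimed beyond the scatter, and the estimated step from compound 1 to compound 4 is a number 2.5 percentage points lower from compound 1 to compound 4 (within the scatter). Compound 4 is therefore expected to give 25% in this assay, within a range from 12% to 38%.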

Compound 4, a percentage reported as inhibition, at one concentration (the size of the read-out at that concentration, not a potency): 29.1%
Estimate against measurement, compound 4: 4.1 percentage points below; low and high end bracket the measured number.
By their numbers in this assay, from the lowest: compound 3; then compounds 2, 1 and 4 (each within the scatter of the next).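

In this assay, pyrazin-2-yl in place of phenyl on the amine nitrogen in the ring gives a number 1.6 percentage points higher from compound 1 to compound 4 (within the scatter). Among the compounds shown here, this is the first reading at this place, since the earlier compounds varied elsewhere, and it shows that a six-membered aromatic ring of carbon only can give way to one with hetero atoms and hydrogen-bond acceptors without a change in the read-out beyond the scatter. No measured property of these compounds is available to account for this outcome.

The compounds shown leave open whether this position would tolerate a group that is not an aromatic ring, such as a methyl group or a longer alkyl chain, to the same extent. They also leave open what an amine or a carboxylic acid carried on the phenyl ring would do to the read-out.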